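The compounds below may be only part of what the source reports. "The series", "measured", "known", "first", "only" and "open" are said of these compounds alone.

Measured so far:
compound 1 `O=C1N=C(NN2Cc3ccccc3N=C2c2ccccc2)S/C1=C/c1ccccc1` — 4050 nM
compound 2 `O=C(CNc1ccc(Br)cc1)Nn1c(-c2ccccc2)nc2ccccc2c1=O` — 15100 nM

Within the data shown here, compound 2 is one of two compounds measured in a functional assay on MCF7 cells (Homo sapiens) for cytotoxicity, read by MTT assay, with a stated time of 4 h; a lower number here means a stronger inhibitor, a higher number a weaker inhibitor. In this assay compound 2 gives 15100 nM, the higher of the two numbers. Compound 1 gives 4050 nM in this assay, a lower number, and the gap between the two lies beyond the scatter; as the two compounds differ in many places, no single change can be read from that gap.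

Compound 3 `O=C(CNc1ccc(Cl)cc1Cl)Nn1c(-c2ccccc2)nc2ccccc2c1=O` is derived from compound 2 by one change: 2,4-dichlorophenyl in place of 4-bromophenyl on an amine nitrogen. Nothing measured here shows how such an exchange of aryl groups on that amine nitrogen bears on this assay, so the step in this assay from compound 2 to compound 3 is expected to be modest, in either direction, and most likely within the scatter. The expected step is a 1.3-fold lower number from compound 2 to compound 3 (0.10 log units; within the scatter). Compound 3 is therefore estimated at 12000 nM, with a range from 4000 nM to 40000 nM.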

Compound 3, half-maximal inhibitory concentration: 4410 nM
The estimate for compound 3 lay 2.7-fold (0.43 log units) above the measured number; measured number inside the range.
By their numbers in this assay, from the lowest: compounds 1 and 3 (each within the scatter of the next); then compound 2.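

Among these compounds, at this position, on an amine nitrogen, the result shows that the aryl group can move the number in this assay: 2,4-dichlorophenyl in place of 4-bromophenyl gives a 3.4-fold lower number from compound 2 to compound 3 (0.53 log units; beyond the scatter) and so the earlier compounds' lack of any single readable change is replaced by one step beyond the scatter. The exchange removes one bromine and brings in two chlorine atoms on the same six-membered aromatic ring of carbon, and neither group carries a net charge. No measurement at hand accounts for the size of this step.

The two compounds do not separate the loss of bromine from the arrival of the two chlorine atoms. On these data alone, how an unsubstituted phenyl, a 4-chlorophenyl or a 4-methoxyphenyl group on that amine nitrogen would read in this assay remains open, as does a cyclohexyl group in place of the aryl ring.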